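The source may report more compounds than this note shows. Statements on the series, on what has been measured and on what is new or still open speak of the compounds shown alone.

Measured so far in a functional assay on B16 cells (Mus musculus) for cytotoxicity, read by MTT assay; on this read-out higher numbers stand for weaker inhibition and lower numbers for stronger inhibition:
compound 1, `CC(=O)O[C@@H]1OC(=O)[C@](C)(C(C)=O)[C@@H]1C`: 4000 nM
compound 2, `CC(=O)O[C@@H]1OC(=O)[C@@](C)(C(C)=O)[C@@H]1C`: 14000 nM
compound 3, `CC(=O)O[C@@H]1OC(=O)[C@@H](C(C)=O)[C@@H]1C`: a limit only, > 50000 nM

Among the measured compounds shown here, only two numbers stand here, and compound 2 holds the higher one, the step being a 3.5-fold higher number from compound 1 to compound 2 (0.54 log units; beyond the scatter), which rests on (the fact that compounds 1 and 2 differ only in the configuration as drawn). For compound 3 the value of > 50000 nM is a limit, not a number, as stated in the limit of > 50000 nM in this assay, at which 1 of the 3 values shown sits.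

Compound 4, `CC(=O)O[C@@H]1OC(=O)[C@@](OC(C)=O)(C(C)=O)[C@@H]1C`, differs from compound 2 by acetoxy in place of methyl on a saturated ring carbon. For the measured compounds named here, the one measured step at that same saturated ring carbon is an at least 12-fold higher number from compound 1 to compound 3 (1.09 log units; beyond the scatter), a large weakening when the methyl is lost. Replacing the methyl by a larger acetoxy is a different change, so compound 4 is expected to give a step of a 1.8-fold higher number from compound 2 to compound 4 (0.25 log units; within the scatter) in this assay, an estimate of 25000 nM, within 8000 nM to 80000 nM.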

Compound 4, half-maximal inhibitory concentration: > 50000 nM
Compound 4: no number, only a limit; the forecaster's own chance of this, stated with the estimate: 30%; at least 2.0-fold (0.30 log units) between middle value and limit.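

Acetoxy in place of methyl on this saturated ring carbon gives an at least 3.5-fold higher number from compound 2 to compound 4 (0.55 log units; beyond the scatter), so the change weakens the result rather than leaving it unchanged. In this assay, from the compounds shown here alone, compound 4 gives only a limit, > 50000 nM, so the full size of the step stays unknown. Among the compounds shown, only the methyl compounds, compound 1 and compound 2, give numbers with this substitution, while the other two stop at the same limit: the limit of > 50000 nM in this assay, at which 2 of the 4 values shown sit.

Going by these compounds, what remains open is whether an ethyl or a hydroxyl group on this carbon would give a number. Also open, on these data alone, is how acetoxy would behave in the configuration of compound 1.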